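The compounds below may be only part of what the source reports. "The series", "measured", "known", "first", "only" and "open" are said of these compounds alone.

Measured so far, in an ADME assay on HT-29 cells (Homo sapiens) for cytotoxicity, read by MTT assay, with a stated time of 72 h; on this read-out lower numbers stand for stronger inhibition and higher numbers for weaker inhibition:
- compound 1 `C=CC(=O)Nc1cc(Nc2ncc3ncn(-c4ccc(C)cc4)c3n2)c(OC)cc1N(C)CCN(C)C` gives 9230 nM
- compound 2 `C=CC(=O)Nc1cc(Nc2ncc3ncn(-c4ccc(C(C)C)cc4)c3n2)c(OC)cc1N(C)CCN(C)C` gives 15300 nM

Compound 2 holds the highest of these two numbers, and its nearest neighbour is compound 1; the step of a 1.7-fold higher number from compound 1 to compound 2 (0.22 log units; within the scatter) lies within the scatter, so the two compounds cannot be told apart on this read-out. Compound 3 `C=CC(=O)Nc1cc(Nc2ncc3ncn(-c4ccc(F)cc4)c3n2)c(OC)cc1N(C)CCN(C)C` is the next compound in line. It differs from compound 2 in one place: fluoro in place of isopropyl on an aromatic carbon.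

Among the measured compounds shown here, only one measured step touches the same aromatic carbon, the one from methyl to isopropyl, and there a 1.7-fold higher number from compound 1 to compound 2 (0.22 log units; within the scatter) stayed within the scatter. Swapping one small group for another at that position therefore gave no change worth the name, and nothing in the measured numbers suggests that putting fluoro there should behave differently. From this, the expected step is a 1.5-fold lower number from compound 2 to compound 3 (0.18 log units; within the scatter), which amounts to nothing beyond the scatter in either direction. Compound 3 is accordingly estimated to give 10000 nM in this assay, with a likely range from 4000 nM to 25000 nM.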

Compound 3, half-maximal inhibitory concentration: 12000 nM
The estimate for compound 3 lay 1.2-fold (0.08 log units) below the measured number, and the stated range covers the measured number.
By their numbers in this assay, from the lowest: compounds 1, 3 and 2 (each within the scatter of the next).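

In this assay, replacing isopropyl with fluoro gives a 1.3-fold lower number from compound 2 to compound 3 (0.11 log units; within the scatter) and replacing methyl with fluoro gives a 1.3-fold higher number from compound 1 to compound 3 (0.11 log units; within the scatter). Among the compounds shown here, the earlier pair compared only two carbon groups, whereas this change swaps 3 carbon atoms for a single fluorine on the same aromatic carbon, para to a large group, and the compounds still cannot be told apart on this read-out. This widens the finding from a swap between carbon groups to a swap between quite different kinds of atom, although it holds only for these three compounds, and nothing available here explains why they read alike.

The compounds shown leave open whether an amine, a carboxylic acid or a longer chain on this carbon would also stay within the scatter or would finally produce a real step. They also leave open whether methyl, isopropyl and fluoro would remain indistinguishable in a different cell line, where this part of the molecule might count for more or less.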